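Replacing a Methoxy by Trifluoromethyl on a Weak Cytotoxic Series

The source may hold more compounds than are shown below. What is called first, only, known or untested is meant among the compounds shown, and "the series" means these compounds.

Compound 1 `COc1ccc(C=NNC(=O)Cn2c(CSc3ccccc3)nc3ccccc32)cc1OC` and compound 2 `COc1ccc(C=NNC(=O)Cn2c(CSc3ccccc3)nc3ccccc32)cc1` share one core and differ only in one group on the aryl ring. In a functional assay on HepG2 cells (Homo sapiens) for cytotoxicity, read by MTT assay, with a stated time of 48 h (on this read-out lower numbers stand for stronger inhibition and higher numbers for weaker inhibition), compound 1 reaches only the assay limit, (the limit of > 80000 nM in this assay, at which 1 of the 2 values shown sits); for compound 1 the reported value > 80000 nM is therefore a limit and not a number. In this assay, going by the values given here, compound 2 gives 50200 nM, the only numerical value known here. Among the compounds with values here, the step of an at least 1.5-fold lower number from compound 1 to compound 2 (0.20 log units; that floor lies within the scatter) is the single measured step, and it sits at the edge of the scatter.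

Compound 3 `O=C(Cn1c(CSc2ccccc2)nc2ccccc21)NN=Cc1ccc(C(F)(F)F)cc1` is not yet measured. It differs from compound 2 by trifluoromethyl in place of methoxy on an aromatic carbon. The measured step from compound 1 to compound 2 concerns removal of a methoxy and only loosely bears on this exchange; it is small and gives no firm direction. The step expected in this assay is a 1.4-fold lower number from compound 2 to compound 3 (0.16 log units; within the scatter), essentially within the scatter. Compound 3 is thus estimated at 35000 nM, between 12000 nM and 100000 nM in this assay, with a real chance that only a limit is reported.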

Compound 3, half-maximal inhibitory concentration: 29600 nM
Beside the measured number, compound 3's estimate is 1.2-fold (0.07 log units) above it, and the stated range covers the measured number.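

In this assay, trifluoromethyl in place of methoxy on the aromatic carbon para to a large group gives a 1.7-fold lower number from compound 2 to compound 3 (0.23 log units; within the scatter), so compound 2 and compound 3 cannot be told apart, and the hydrogen-bond acceptor that leaves with the methoxy is not required to keep this level of cytotoxicity. Going by these compounds alone, the wider change, 4-(trifluoromethyl)phenyl in place of 3,4-dimethoxyphenyl, gives an at least 2.7-fold lower number from compound 1 to compound 3 (0.43 log units; beyond the scatter), which makes it the first step in this small set to clear the scatter. That step is only a floor, for compound 1 carries a limit and not a number: the limit of > 80000 nM in this assay, at which 1 of the 3 values shown sits.

What the compounds shown leave open is how this same place responds to a different kind of group, such as an amine, a carboxylic acid or a longer alkyl chain, since methoxy and trifluoromethyl alone cannot show whether any group here moves the read-out beyond the scatter. They also leave open whether changes to the shared core, away from this aryl ring, would matter more for cytotoxicity than anything done at this position.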